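From a Chain to a Five-Membered Ring on the Alkyne

The source may hold more compounds than are shown below. What is called first, only, known or untested is meant among the compounds shown, and "the series" means these compounds.

Two compounds share a core and differ only in the group on a triple-bonded carbon. In an ADME assay on the whole organism (Rattus norvegicus) for pharmacokinetics, at a dose of 3 mg/kg by the intravenous route (a higher number here means that more of the compound sits outside the plasma, a lower number that more of the compound stays in the plasma), compound 1 `NC(=O)c1cc(Cl)c2c(Cl)c(C#CC3CCOCC3)n([C@H]3CCCNC3)c2n1` gives 63 L/kg, and compound 2 `COCCC#Cc1c(Cl)c2c(Cl)cc(C(N)=O)nc2n1[C@H]1CCCNC1` gives 18.6 L/kg, the lowest of the two numbers. Among the measured compounds shown here, the one step seen, a 3.4-fold lower number from compound 1 to compound 2 (0.53 log units; beyond the scatter), was modest but beyond the scatter. Compound 3 `NC(=O)c1cc(Cl)c2c(Cl)c(C#CC3CCCO3)n([C@H]3CCCNC3)c2n1` brings a related change: oxolan-2-yl in place of 2-methoxyethyl on a triple-bonded carbon. Since a ring replaced by a chain gave a lower number, a chain replaced by a ring is expected to move the number back up, so a 1.9-fold higher number from compound 2 to compound 3 (0.27 log units; within the scatter) is expected. Compound 3 is therefore estimated at 35 L/kg, within 15 L/kg to 80 L/kg.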

Compound 3, volume of distribution at steady state: 19.6 L/kg
For compound 3 the middle estimate is 1.8-fold (0.25 log units) above the measured one, within the range that was stated.
By their numbers in this assay, from the lowest: compounds 2 and 3 (each within the scatter of the next); then compound 1.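

In this assay the step of a 1.1-fold higher number from compound 2 to compound 3 (0.02 log units; within the scatter) puts oxolan-2-yl level with 2-methoxyethyl, so having a ring on the triple-bonded carbon does not by itself raise the number. The step of a 3.2-fold lower number from compound 1 to compound 3 (0.51 log units; beyond the scatter) separates oxolan-2-yl from oxan-4-yl, so among these three compounds, only the one carrying the six-membered ring stands apart. Nothing measured here explains this difference. Still open, on these data alone, is how an amine or a carboxylic acid on the triple-bonded carbon would read, and whether a longer chain would stay level with 2-methoxyethyl.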